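This account rests on a few compounds, and the source may have more. Where it says the series, first, only, none or still open, it means among the compounds named here.

The measured compounds:

Compound 1, `CCc1ccc(SCc2ccc(/C=C/C(=O)Nc3ccccc3N)cc2)cc1`, gives "not determined" (no result reported) in a functional assay on HeLa cells (Homo sapiens) for antiproliferative activity, read by CCK-8 assay, with a stated time of 72 h; a higher number here means a weaker inhibitor, a lower number a stronger inhibitor.
Compound 2, `COc1ccc(SCc2ccc(C(=O)Nc3ccccc3N)cc2)cc1`, gives 2390 nM in this assay.
Compound 3, `Cc1ccc(SCc2ccc(C(=O)Nc3ccccc3N)cc2)cc1`, gives 4250 nM in this assay.

Among the measured compounds shown here, compound 3 therefore holds the higher of the two numbers recorded, and its only neighbour is compound 2: the step of a 1.8-fold higher number from compound 2 to compound 3 (0.25 log units; within the scatter) is within the scatter, so the two compounds cannot be ranked against each other.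

Compound 4, `Nc1ccccc1NC(=O)c1ccc(CSc2ccc(Cl)cc2)cc1`, is not yet measured. It differs from compound 3 as follows: chloro in place of methyl on an aromatic carbon. For the measured compounds named here, no measured step carries this exchange of chloro for methyl, so there is no direct precedent. Going by the values given here, the one step that touches the same aromatic carbon, a 1.8-fold higher number from compound 2 to compound 3 (0.25 log units; within the scatter), exchanged two other groups and stayed within the scatter, which suggests that a single small group at this carbon has so far moved the number little. On that basis compound 4 is expected to sit near compound 3, with a step of a 1.2-fold lower number from compound 3 to compound 4 (0.08 log units; within the scatter) that is expected to lie within the scatter. The estimate for compound 4 is 3500 nM, with a range from 1500 nM to 8000 nM.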

Compound 4, half-maximal inhibitory concentration: 12700 nM
The estimate for compound 4 lay 3.6-fold (0.56 log units) below the measured number; measured number outside the range, above it.
By their numbers in this assay, from the lowest: compounds 2 and 3 (each within the scatter of the next); then compound 4.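

In this assay, among the compounds shown here, the aromatic carbon para to a large group proves sensitive to a single small group: going from 4-methylphenyl to 4-chlorophenyl gives a 3.0-fold higher number from compound 3 to compound 4 (0.48 log units; beyond the scatter) and is the first step at this carbon that lies beyond the scatter. Chloro also separates from methoxy, with a 5.3-fold higher number from compound 2 to compound 4 (0.73 log units; beyond the scatter) on record, so among the three groups seen here chloro alone stands apart, while methyl and methoxy cannot be ranked against each other. Nothing at hand accounts for the higher number that chloro gives.

As far as these compounds go, it remains open whether bromo or fluoro at this carbon would follow chloro, and what an amine or a carboxylic acid there would do. The compounds shown also leave open whether chloro on another carbon of this ring would give a similar step.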